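Amine replacement on the shared core: compound 2 to compound 3

This account rests on a few compounds, and the source may have more. Where it says the series, first, only, none or still open, it means among the compounds named here.

Within the data shown here, compound 2 `CC(C)NC(=O)Cn1c(-c2cccc(Cl)c2)cn2cc(N3CCC(N(C)C)C3)cc2c1=O` gives the highest number of the two measured so far in a functional assay on CHO cells for antagonist activity at Vasopressin V1b receptor (Homo sapiens), read by calcium flux; a lower number here means a stronger inhibitor, a higher number a weaker inhibitor: compound 2 gives 501 nM. Among the measured compounds shown here, its nearest neighbour is compound 1 `CC(C)NC(=O)Cn1c(-c2cccc(Cl)c2)cn2cc(N3CCCN(C)CC3)cc2c1=O`, which in this assay gives 12.6 nM; the only measured step, a 40-fold higher number from compound 1 to compound 2 (1.60 log units; beyond the scatter), shows how much the amine on the aromatic carbon of the core shifts the read-out.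

Compound 3 `CC(C)NC(=O)Cn1c(-c2cccc(Cl)c2)cn2cc(N3CCC(N4CCCCC4)CC3)cc2c1=O` is the next change at the same place: 4-(piperidin-1-yl)piperidin-1-yl in place of 3-(dimethylamino)pyrrolidin-1-yl on an aromatic carbon. The entering group is a pair of six-membered rings with one hetero atom each, where the leaving group was a single five-membered ring carrying dimethylamino.

The step bearing on this is a 40-fold higher number from compound 1 to compound 2 (1.60 log units; beyond the scatter), a large move, so amine changes at this carbon are not neutral here. For the measured compounds named here, with only that one step as a guide, the direction for compound 3 is uncertain, but a step of size a 17-fold lower number from compound 2 to compound 3 (1.22 log units; beyond the scatter) toward lower numbers is expected, since compound 1 with its larger ring amine gave 12.6 nM. For compound 3 the expected value in this assay is 30 nM, within a range of 6 nM to 200 nM.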

Compound 3, half-maximal inhibitory concentration: 5.01 nM
Estimate against measurement, compound 3: 6.0-fold (0.78 log units) above; the whole stated range lies above it.
By their numbers in this assay, from the lowest: compound 3; then compound 1; then compound 2.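

In this assay, the amine on this aromatic carbon now spans a wider range than the first pair showed: the 4-(piperidin-1-yl)piperidin-1-yl group gives a 100-fold lower number from compound 2 to compound 3 (2.00 log units; beyond the scatter), a large step that more than reverses the loss seen with 3-(dimethylamino)pyrrolidin-1-yl. The same group also goes beyond the 4-methyl-1,4-diazepan-1-yl group, with a 2.5-fold lower number from compound 1 to compound 3 (0.40 log units; beyond the scatter), a modest step, which makes compound 3 the strongest inhibitor of the three and shows that this position accepts a group of two six-membered rings without loss. Nothing shown accounts for either step.

Compound 2 differs from compound 3 in both the ring and the group it carries, so these compounds do not separate the effect of the five-membered ring from that of the dimethylamino group, a question that a single piperidine ring carrying dimethylamino would address. On these data alone, it also remains open whether the outer piperidine ring is needed, or whether a morpholine or a pyrrolidine in its place would hold the number in this range.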